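The compounds below may be only part of what the source reports. "The series", "measured", "known", "first", "only" and "open" are said of these compounds alone.

Compound 1 `CNC(=O)c1cc(Oc2cccc(NC(=S)Nc3ccc(F)c(F)c3)c2)ccn1`: in a functional assay on MDA-MB-231 cells (Homo sapiens) for cytotoxicity, read by MTT assay, with a stated time of 48 h (on this read-out higher numbers stand for weaker inhibition and lower numbers for stronger inhibition), compound 1 gives a value that is a limit of the assay, > 100000 nM.
Compound 2 `CCNC(=O)c1cc(Oc2cccc(NC(=S)Nc3ccc(F)c(F)c3)c2)ccn1`: in this assay compound 2 likewise gives only a limit, > 100000 nM.
Compound 3 `O=C(NC1CCCCC1)c1cc(Oc2cccc(NC(=S)Nc3ccc(F)c(F)c3)c2)ccn1`: in this assay compound 3 also gives only a limit, > 100000 nM.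

Compound 3 therefore stands at the same limit as the other two; none of the three has a readable number, and the steps among them are a step that the two limits leave unreadable from compound 1 to compound 2, a step that the two limits leave unreadable from compound 1 to compound 3 and a step that the two limits leave unreadable from compound 2 to compound 3. The whole picture rests on (the limit of > 100000 nM in this assay, at which 3 of the 3 values shown sit).

Compound 4 `O=C(c1cc(Oc2cccc(NC(=S)Nc3ccc(F)c(F)c3)c2)ccn1)N1CCCC1` differs from compound 3 in one place: pyrrolidin-1-yl in place of cyclohexylamino on a carbonyl carbon. The measured steps that bear on this change are those among compounds 1, 2 and 3, all of which alter the group on the amide-type nitrogen of the shared core, and none of them could be read, because every value sits at the limit (the limit of > 100000 nM in this assay, at which 3 of the 3 values shown sit). Among the compounds with values here, nothing among the measured compounds shows that a change at this carbonyl carbon moves the read-out in either direction.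

Compound 4 is expected to give a value in this assay of 150000 nM, within 40000 nM to 500000 nM. The expected step from compound 3 to compound 4 is a step that the limit leaves unreadable from compound 3 to compound 4, most likely again reported only as a limit.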

Compound 4, half-maximal inhibitory concentration: > 100000 nM
Compound 4: no number, only a limit; the forecaster's own chance of this, stated with the estimate: 85%; the middle value does not contradict the limit.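

In this assay compound 4 gives > 100000 nM as a limit of the assay and not a number. Its steps from compound 1, compound 2 and compound 3 therefore cannot be read: the limit of > 100000 nM in this assay, at which 4 of the 4 values shown sit. The compounds shown leave open whether any group on this carbonyl carbon gives a readable value in this assay at all.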